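A few compounds are considered here, and "the series" means these few. Any claim that something is new, unique, unknown or untested is made for them only; others in the source may bear on it.

Three compounds share one core and differ only in the aryl group carried on an oxygen on a saturated carbon. Compound 1 `Cc1c(OC[C@@H](C)COc2ccc(Cl)c(C(=O)O)c2)ccc(C(=O)CC(C)(C)C)c1O` gives 377 nM in an assay for positive allosteric modulation of metabotropic glutamate receptor 2 (Rattus norvegicus); on this read-out higher numbers stand for an effect only at larger amounts of compound and lower numbers for an effect already at smaller amounts. Compound 2 `Cc1cc(C(=O)O)ccc1OC[C@H](C)COc1ccc(C(=O)CC(C)(C)C)c(O)c1C` gives 446 nM in this assay, and compound 3 `Cc1c(OC[C@@H](C)COc2ccc(C(=O)O)cc2F)ccc(C(=O)CC(C)(C)C)c1O` gives 222 nM. Within the data shown here, of the three numbers, the one for compound 3 is the smallest, yet the steps of a 1.7-fold lower number from compound 1 to compound 3 (0.23 log units; within the scatter) and a 2.0-fold lower number from compound 2 to compound 3 (0.30 log units; within the scatter) both remain within the scatter, as does a 1.2-fold higher number from compound 1 to compound 2 (0.07 log units; within the scatter), so the three values cannot be told apart with confidence.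

Compound 4 `Cc1cc(OC[C@H](C)COc2ccc(C(=O)CC(C)(C)C)c(O)c2C)ccc1C(=O)O` has not yet been measured. It differs from compound 3 in one place: 4-carboxy-3-methylphenyl in place of 4-carboxy-2-fluorophenyl on an oxygen on a saturated carbon. All three measured steps bear on this change, since each of them also swaps or alters the substituents on this same aryl group, and none of them moved the number beyond the scatter. A step of comparable size, not beyond the scatter, is therefore expected from compound 3 to compound 4, namely a 1.5-fold higher number from compound 3 to compound 4 (0.17 log units; within the scatter). Compound 4 is expected to give about 330 nM in this assay, with a range from 150 nM to 750 nM.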

Compound 4, half-maximal effective concentration: 305 nM
Compound 4: the middle estimate sits 1.1-fold (0.03 log units) above what was measured; the range from low to high includes it.
By their numbers in this assay, from the lowest: compounds 3, 4, 1 and 2 (each within the scatter of the next).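

In this assay, replacing the 4-carboxy-2-fluorophenyl group with 4-carboxy-3-methylphenyl gives a 1.4-fold higher number from compound 3 to compound 4 (0.14 log units; within the scatter) and so does not separate the two groups. The new compound also provides the first pair whose aryl groups differ only in the number that places the methyl in the name, 4-carboxy-2-methylphenyl and 4-carboxy-3-methylphenyl, and this single move gives a 1.5-fold lower number from compound 2 to compound 4 (0.17 log units; within the scatter) without a change that can be told from the scatter. The exchange for the 3-carboxy-4-chlorophenyl group gives a 1.2-fold lower number from compound 1 to compound 4 (0.09 log units; within the scatter) and points the same way, so none of the four aryl groups on this oxygen can be told apart from any other in this read-out, whether it carries chloro, fluoro or methyl.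

The compounds shown leave open whether the number would hold if a tetrazole or a primary amide replaced the carboxylic acid, or if a longer chain joined the carboxylic acid to the ring, since every aryl group here carries the acid directly on the ring. There is also no measurement at hand that explains why these four groups give such similar numbers.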